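From fluoro to chloro on an aromatic carbon

A few compounds are considered here, and "the series" means these few. Any claim that something is new, unique, unknown or untested is made for them only; others in the source may bear on it.

compound 1 `COc1cc(C(=O)c2cn(-c3ccc(C)cc3)cc2-c2ccccc2Cl)cc(OC)c1OC` gives 180 nM
compound 2 `COc1cc(C(=O)c2cn(-c3ccc(F)cc3)cc2-c2ccccc2Cl)cc(OC)c1OC` gives 83 nM
compound 3 `COc1cc(C(=O)c2cn(-c3ccc(N)cc3)cc2-c2ccccc2F)cc(OC)c1OC` gives 28 nM

In a functional assay on MCF7 cells (Homo sapiens) for cytotoxicity, read by MTT assay, with a stated time of 96 h (a lower number here means a stronger inhibitor, a higher number a weaker inhibitor), compound 3 at 28 nM has the lowest number of the three. Compound 4 `COc1cc(C(=O)c2cn(-c3ccc(N)cc3)cc2-c2ccccc2Cl)cc(OC)c1OC` differs from it in one group: chloro in place of fluoro on an aromatic carbon, with chloro in place of fluoro on an aromatic carbon, ortho to a large group. Among the measured compounds shown here, no measured step makes this swap. The closest guide is a 2.2-fold lower number from compound 1 to compound 2 (0.34 log units; beyond the scatter), a modest step at a different place. Compound 1 and compound 2 carry chloro but also differ from compound 3 in a second group, so they offer only a hint of direction. The expected step is small, leaning toward a higher number, at a 1.4-fold higher number from compound 3 to compound 4 (0.15 log units; within the scatter) as estimated here. For compound 4 the estimated value is 40 nM, with an expected range from 15 nM to 100 nM in this assay.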

Compound 4, half-maximal inhibitory concentration: 83 nM
The estimate for compound 4 lay 2.1-fold (0.32 log units) below the measured number; low and high end bracket the measured number.
By their numbers in this assay, from the lowest: compound 3; then compounds 2 and 4 (each within the scatter of the next); then compound 1.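

In this assay, among the compounds shown here, replacing 2-fluorophenyl with 2-chlorophenyl gives a 3.0-fold higher number from compound 3 to compound 4 (0.47 log units; beyond the scatter), the first direct reading of this change at this position. With chloro held in place, amino in place of methyl gives a 2.2-fold lower number from compound 1 to compound 4 (0.34 log units; beyond the scatter), so the group changed in that step also affects the number. Amino in place of fluoro gives no change at the digits printed from compound 2 to compound 4 (within the scatter), so these two groups cannot be told apart here when chloro is present. Nothing available explains these steps. From the compounds shown here alone, how bromo or a nitrile would read in place of the chloro remains open.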